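Shortening the Linker Between Core and Iodoacetamide

The compounds below may be only part of what the source reports. "The series", "measured", "known", "first", "only" and "open" are said of these compounds alone.

Measured compounds:
Compound 1 `O=C(CI)NCCCCCCCCNc1ncnc2c1ncn2[C@@H]1O[C@H](COP(=O)(O)OP(=O)(O)OP(=O)(O)O)[C@@H](O)[C@H]1O`: 47%
Compound 2 `O=C(CI)NCCCC(=O)NCCCCCCNc1ncnc2c1ncn2[C@@H]1O[C@H](COP(=O)(O)OP(=O)(O)OP(=O)(O)O)[C@@H](O)[C@H]1O`: 0%

In an assay on isolated protein for inhibition of hexokinase-3 (Rattus norvegicus), with a stated time of 6 h, tested at 10 mM (a higher number here means more inhibition at the concentration tested (going by the name of the read-out), a lower number less inhibition), compound 1 gives 47%, while compound 2 gives 0%. Within the data shown here, compound 2 thus stands lowest of the two numbers, with compound 1 its only neighbour, and the single step of the set, a number 47 percentage points lower from compound 1 to compound 2 (beyond the scatter), separates them. Compound 3 `O=C(CI)NCCCCCCCNc1ncnc2c1ncn2[C@@H]1O[C@H](COP(=O)(O)OP(=O)(O)OP(=O)(O)O)[C@@H](O)[C@H]1O` differs from compound 2 as follows: a group of 6 heavy atoms (3 carbon, 1 nitrogen, 1 oxygen, 1 iodine; no ring) in place of a group of 11 heavy atoms (6 carbon, 2 nitrogen, 2 oxygen, 1 iodine; no ring), on a saturated chain carbon, six bonds along the chain from a nitrogen on an aromatic ring. Among the measured compounds shown here, this change largely reverses the one measured step, which was large, so a rise in this assay is expected for compound 3, estimated as a number 30 percentage points higher from compound 2 to compound 3 (beyond the scatter). Compound 3 is accordingly expected to give 30%, within 5% to 60%.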

Compound 3, a percentage reported as inhibition, at one concentration (the size of the read-out at that concentration, not a potency): 20%
Beside the measured number, compound 3's estimate is 10 percentage points above it; low and high end bracket the measured number.
By their numbers in this assay, from the lowest: compound 2; then compound 3; then compound 1.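

In this assay, putting (((iodomethyl)carbonyl)amino)methyl in place of the larger group gives a number 20 percentage points higher from compound 2 to compound 3 (beyond the scatter), so part of the earlier loss returns. The return is only partial: ((iodomethyl)carbonyl)amino in place of (((iodomethyl)carbonyl)amino)methyl gives a number 27 percentage points lower from compound 1 to compound 3 (beyond the scatter), showing that this small change on the chain also registers beyond the scatter. Nothing available explains either step. Going by these compounds, whether a longer chain than that of compound 1 would raise the number further remains open. So does the effect of an amine or a carboxylic acid at this position.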